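A few compounds are considered here, and "the series" means these few. Any claim that something is new, unique, unknown or untested is made for them only; others in the source may bear on it.

- compound 1 `Cc1ccc(-c2c3c(nc(C)c2[C@H](OC(C)(C)C)C(=O)O)CCN(CCCc2ccccc2)C3)cc1` gives > 40000 nM (a limit)
- compound 2 `Cc1nc2c(c(-c3cc(F)c4c(c3C)CCCO4)c1[C@H](OC(C)(C)C)C(=O)O)CN(CCCc1ccc(F)cc1)CC2` gives > 40000 nM (a limit)

In an ADME assay on MT2 cells (Homo sapiens) for cytotoxicity, read by XTT assay, with a stated time of 4 days (a higher number here means that more compound is tolerated, a lower number that less compound is tolerated), compound 2 gives only a limit of the assay and no number (> 40000 nM). Compound 1 also gives only a limit (> 40000 nM). Among the measured compounds shown here, compound 2 therefore stands at the limit of > 40000 nM in this assay, at which 2 of the 2 values shown sit, and no measured step is available for comparison.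

Compound 3 `Cc1nc2c(c(-c3cc(F)c4c(c3C)CCCO4)c1[C@H](OC(C)(C)C)C(=O)O)CN(CCCc1ccccc1)CC2` differs from compound 2 in one place, with hydrogen in place of fluoro on an aromatic carbon, 4-fluorophenyl to phenyl (hydrogen in place of fluoro on an aromatic carbon). The expected change in this assay is none beyond the scatter (a number no higher from compound 2 to compound 3 (the limit leaves the size open)). Compound 3 is estimated at 40000 nM (range 20000 nM to 80000 nM).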

Compound 3, half-maximal cytotoxic concentration: > 40000 nM
Compound 3: a limit, no number; the forecaster's own chance of this, stated with the estimate: 85%; the middle value lies on the limit itself.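

Among the compounds shown here, compound 1, compound 2 and compound 3 all give limits, not numbers, in this assay, so no step from compound 1 or compound 2 to compound 3 can be read. Open remains the concentration at which any of these three compounds becomes cytotoxic, and whether 4-fluorophenyl to phenyl alters it.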